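Methylamino in place of the amide ether on the shared core

This account rests on a few compounds, and the source may have more. Where it says the series, first, only, none or still open, it means among the compounds named here.

Of the compounds shown here, three on one core have been measured in an assay on isolated protein (strain Sprague-Dawley) for inhibition of Amine oxidase [flavin-containing] B (Rattus norvegicus), read by spectrophotometry, with a stated time of 5 min; on this read-out higher numbers stand for weaker inhibition and lower numbers for stronger inhibition. Compound 1 `CCCOc1cc(=O)oc2cc(OCc3ccccc3)ccc12` gives 575 nM, compound 2 `CCOc1cc(=O)oc2cc(OCc3cccc(Br)c3)ccc12` gives 126 nM and compound 3 `CNC(=O)COc1cc(=O)oc2cc(OCc3cccc(Cl)c3)ccc12` gives 33.9 nM. Compound 3 stands lowest of the three numbers; the gap to compound 2 lies beyond the scatter, and the gap to compound 1 is wider still. Compound 4 `CNc1cc(=O)oc2cc(OCc3cccc(Cl)c3)ccc12` differs from compound 3 in one place: methylamino in place of (methylcarbamoyl)methoxy on an aromatic carbon. Among the measured compounds shown here, no measured pair shows this change, so nothing in the set tells its direction. A moderate weakening is expected from compound 3 to compound 4, a 3.2-fold higher number from compound 3 to compound 4 (0.51 log units; beyond the scatter), with wide uncertainty. Compound 4 is estimated at 110 nM, in a range from 20 nM to 600 nM.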

Compound 4, half-maximal inhibitory concentration: 8.71 nM
For compound 4 the middle estimate is 13-fold (1.10 log units) above the measured one; the measured number lies below the stated range.
By their numbers in this assay, from the lowest: compound 4; then compound 3; then compound 2; then compound 1.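

Among the compounds shown here, at this position on the shared core, the 6 heavy atoms of (methylcarbamoyl)methoxy are not needed for inhibition: methylamino in their place gives a 3.9-fold lower number from compound 3 to compound 4 (0.59 log units; beyond the scatter) and is the first one-place comparison. Nothing at hand bears on why the number falls.

Still open, as far as these compounds go, is whether the gain follows the nitrogen on the aromatic carbon or the shorter group, since the step from compound 3 changes both at once. Methoxy, an unsubstituted amine or ethylamino at this position would help separate the two.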